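This account rests on a few compounds, and the source may have more. Where it says the series, first, only, none or still open, it means among the compounds named here.

In an assay on cells for inhibition of Palmitoleoyl-protein carboxylesterase NOTUM variant C330S (Homo sapiens), read by fluorescence, with a stated time of 40 min (a lower number here means a stronger inhibitor, a higher number a weaker inhibitor), three compounds have been measured. Compound 1 `Cc1[nH]c(C(F)(F)F)cc1C(=O)O` gives 6700 nM, compound 2 `Cc1cc(C(=O)O)c(C)n1CC1CC1` gives 12700 nM, and compound 3 `O=C(O)C1CCN(c2ccccc2)C1` gives 48000 nM. Compound 3 therefore stands highest of the three numbers and is the weakest inhibitor of the set; its nearest neighbour is compound 2, whose lower number lies beyond the scatter, and compound 1 is lower still, also beyond the scatter.

Compound 4 `O=C(O)C1CCN(c2ccccc2F)C1` is not yet measured. It differs from compound 3 in one place only: fluoro in place of hydrogen on an aromatic carbon. Among the measured compounds shown here, no pair of measured compounds differs by a single such change, so nothing measured here tells how large this step should be. The account therefore expects only a modest step, if any, with a slight lean toward a lower number, and the expected step is a 1.6-fold lower number from compound 3 to compound 4 (0.20 log units; within the scatter), small enough that it may well sit within the scatter. For compound 4 the estimate in this assay is 30000 nM, with a range from 10000 nM to 90000 nM.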

Compound 4, half-maximal inhibitory concentration: 11000 nM
Beside the measured number, compound 4's estimate is 2.7-fold (0.44 log units) above it; low and high end bracket the measured number.
By their numbers in this assay, from the lowest: compounds 1, 4 and 2 (each within the scatter of the next); then compound 3.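

In this assay, fluoro in place of hydrogen on an aromatic carbon gives a 4.4-fold lower number from compound 3 to compound 4 (0.64 log units; beyond the scatter) and so provides the first measured effect of a single-place change among these compounds. Among the compounds shown here, this place on the six-membered aromatic ring, ortho to a group of 8 heavy atoms, thus responds to the addition of one heavy atom, something the earlier compounds, with no single-place pair among them, could not show. Nothing available gives a measured reason for this step.

On these data alone, whether the gain is particular to fluoro, or would also appear with chloro, methyl or methoxy in the same place, remains open. As far as these compounds go, it is also open whether fluoro on the other aromatic carbons of that ring would give a step of similar size.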